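This account rests on a few compounds, and the source may have more. Where it says the series, first, only, none or still open, it means among the compounds named here.

Compound 1 `COc1cc(-c2nnc(SCC(=O)c3ccc(Cl)cc3)n2N)cc(OC)c1OC` gives, in a functional assay on PC-3 cells (Homo sapiens) for antiproliferative activity, read by MTT assay, with a stated time of 48 h (a higher number here means a weaker inhibitor, a lower number a stronger inhibitor), a value that is a limit of the assay: > 100000 nM.
Compound 2 `COc1cc(-c2nnc(SCC(=O)c3ccc(Br)cc3)n2N)cc(OC)c1OC` likewise gives only a limit in this assay: > 100000 nM.
Compound 3 `COc1ccc(C(=O)CSc2nnc(-c3cc(OC)c(OC)c(OC)c3)n2N)cc1` gives in this assay a number, 97900 nM.

Within the data shown here, compound 3 holds the only measured number in the set, the other two values being limits (the limit of > 100000 nM in this assay, at which 2 of the 3 values shown sit). The steps from the limits to it, an at least 1.0-fold lower number from compound 1 to compound 3 (0.00 log units; that floor lies within the scatter) and an at least 1.0-fold lower number from compound 2 to compound 3 (0.00 log units; that floor lies within the scatter), have floors that lie within the scatter, and the step that the two limits leave unreadable from compound 1 to compound 2 cannot be read at all. Compound 4 `COc1cc(-c2nnc(SCC(=O)NCc3ccc(Cl)cc3)n2N)cc(OC)c1OC` differs from compound 3 by (4-chlorobenzyl)amino in place of 4-methoxyphenyl on a carbonyl carbon. Among the measured compounds shown here, none of the measured steps touches this carbonyl carbon; all three swap a substituent on the aromatic ring, so they give no guidance on the size or direction of the change to the amide. What they do show is that every compound of this shared core sits at or beyond the upper edge of the assay. Compound 4 is therefore expected to remain in that region, with the step of a 1.0-fold higher number from compound 3 to compound 4 (0.01 log units; within the scatter) estimated to lie within the scatter. Compound 4 is estimated to give 100000 nM, with a range from 30000 nM to 300000 nM, and a fair chance that only a limit is reported.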

Compound 4, half-maximal inhibitory concentration: > 100000 nM
Compound 4: a limit, no number (the forecaster's own chance of this, stated with the estimate: 55%); the middle value sits exactly at the limit.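

Among these compounds, compounds 1 to 3 differ only in a substituent on an aromatic ring, whereas compound 4 is the first to show a change on the carbonyl carbon, where (4-chlorobenzyl)amino, with its hydrogen-bond donor, replaces the aryl group. In this assay, the replacement of 4-methoxyphenyl gives an at least 1.0-fold higher number from compound 3 to compound 4 (0.00 log units; that floor lies within the scatter), so the amide shows no readable gain in antiproliferative activity, while the steps from compound 1 and compound 2 to compound 4 cannot be read, as each joins two limits. The limit now extends from changes on the aromatic ring to this different group on the carbonyl carbon: the limit of > 100000 nM in this assay, at which 3 of the 4 values shown sit.

How far compound 4 lies past its limit stays open, so the true size of its step from compound 3 is unknown, and the shown compounds cannot separate the effect of the amide nitrogen from that of the benzyl chain. Also open, going by these compounds, is whether a carboxylic acid, a morpholine amide or a longer chain on this carbonyl carbon would give a number in this assay.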